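This account rests on a few compounds, and the source may have more. Where it says the series, first, only, none or still open, it means among the compounds named here.

Measured so far:
Compound 1 `N#Cc1ccc(OCCn2ccc(=O)n(Cc3ccccc3)c2=O)cc1`: 166000 nM
Compound 2 `Cc1ccc(OCCn2ccc(=O)n(Cc3cccc(C)c3)c2=O)cc1`: >= 38000 nM

Both values come from an ADME assay on MT4 cells (Homo sapiens) for cytotoxicity, read by MTT assay, with a stated time of 4 days; a lower number here means that less compound is tolerated, a higher number that more compound is tolerated. For compound 2, the reading of >= 38000 nM is only a limit and not a number. Compound 3 `Cc1ccc(OCCn2ccc(=O)n(Cc3cc(C)cc(C)c3)c2=O)cc1` differs from compound 2 by one change: methyl in place of hydrogen on an aromatic carbon. This places methyl in place of hydrogen on an aromatic carbon, turning 3-methylbenzyl into 3,5-dimethylbenzyl. Among the measured compounds shown here, no measured pair shows what this change does, so no direction is favoured. The expected step that the limit leaves unreadable from compound 2 to compound 3 stays within the usual scatter. For compound 3, the estimated value is 40000 nM, with an expected range of 15000 nM to 170000 nM.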

Compound 3, half-maximal cytotoxic concentration: > 343000 nM
Compound 3: a limit, no number (the forecaster's own chance of this, stated with the estimate: 60%); middle value at least 8.5-fold (0.93 log units) from the limit.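

Among the compounds shown here, the readings for compound 2 and compound 3 are both limits and not numbers, and no step between them can be read. The compounds shown leave open what turning 3-methylbenzyl into 3,5-dimethylbenzyl does to the reading.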